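Shortening a Long Acyl Chain: Expected Effect on Cytotoxicity

This account rests on a few compounds, and the source may have more. Where it says the series, first, only, none or still open, it means among the compounds named here.

Measured so far:
compound 1 `CCCCCCCCCCCCCCCCCCCCCC(=O)O[C@H]1[C@H](O)[C@H](n2ccc(N)nc2=O)O[C@@H]1CO`: 1.1 ug/mL
compound 2 `CCCCCCCC/C=C\CCCCCCCCCCCC(=O)OC[C@H]1O[C@@H](n2ccc(N)nc2=O)[C@@H](O)[C@@H]1OC(=O)CCCCCCCCCCC/C=C\CCCCCCCC`: > 10 ug/mL (a limit of the assay, not a number)

In a functional assay on HeLa cells (Homo sapiens) for cytotoxicity, read by cell counting, with a stated time of 48 h (a lower number here means that less compound is needed, a higher number that more compound is needed for the effect), compound 1 gives 1.1 ug/mL. Compound 2 reaches only > 10 ug/mL, which is a limit of the assay rather than a measured number. For the measured compounds named here, compound 1 therefore carries the only definite value here, while the other result sits at the limit of > 10 ug/mL in this assay, at which 1 of the 2 values shown sits. Going by the values given here, no step between two measured compounds is available to calibrate how a change in the acyl chain moves this read-out.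

Compound 3 `CCCCCCCCCCCCCCCCCC(=O)O[C@H]1[C@H](O)[C@H](n2ccc(N)nc2=O)O[C@@H]1CO` keeps the core of compound 1 and differs only in the length of its single ester chain: hydrogen in place of butyl on a saturated chain carbon, ten or more bonds along the chain from a carbonyl carbon. Without a measured step to lean on, the expectation is a small shift toward a higher number, close to the edge of the usual scatter, so compound 3 is estimated at 2 ug/mL, with a range from 0.6 ug/mL to 6 ug/mL, meaning an expected step of a 1.8-fold higher number from compound 1 to compound 3 (0.26 log units; within the scatter).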

Compound 3, concentration for half-maximal effect: 0.13 ug/mL
Compound 3: the middle estimate sits 15-fold (1.19 log units) above what was measured; the measured number lies below the stated range.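

Hydrogen in place of butyl on a saturated chain carbon gives an 8.5-fold lower number from compound 1 to compound 3 (0.93 log units; beyond the scatter) in this assay. The earlier compounds shown here offered no step of this kind, and this one shows that the read-out responds to a change this far along the chain: with the shorter chain, less compound is needed for the effect. Nothing measured here explains why the shorter chain has this effect.

As far as these compounds go, a single step gives one direction and no trend, so it remains open whether a still shorter chain would lower the number further or raise it again. From the compounds shown here alone, it also remains open how a chain ending in an amine or a carboxylic acid would behave at this place.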